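Replacing Dimethylamino with a Longer Basic Ether Chain

The compounds below may be only part of what the source reports. "The series", "measured", "known", "first", "only" and "open" are said of these compounds alone.

Measured compounds:
- Compound 1 `Nc1ccc(-c2cc(=O)c3c(N)c(F)cc(F)c3o2)cc1F`: in a functional assay on HeLa cells (Homo sapiens) for cytotoxicity, read by neutral red uptake, with a stated time of 3 days (a lower number here means a stronger inhibitor, a higher number a weaker inhibitor), compound 1 gives > 100000 nM, which is a limit of the assay rather than a number.
- Compound 2 `CN(C)c1c(F)c(N)c2c(=O)cc(-c3ccc(N)c(F)c3)oc2c1F`: in this assay compound 2 gives > 100000 nM, again a limit of the assay rather than a number.

Compound 2 therefore stands at the limit, and compound 1 sits there too; (the limit of > 100000 nM in this assay, at which 2 of the 2 values shown sit). For the measured compounds named here, the only measured step, a step that the two limits leave unreadable from compound 1 to compound 2, is for that reason unreadable: two limits cannot reveal either a direction or a size.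

Compound 3, `CN(C)CCCOCc1c(F)c(N)c2c(=O)cc(-c3ccc(N)c(F)c3)oc2c1F`, arises from compound 2 by (3-(dimethylamino)propoxy)methyl in place of dimethylamino on an aromatic carbon. Going by the values given here, no measured step bears directly on this change, and the one step that does exist, running between two limits, offers no size to carry over. The expectation is therefore simply that compound 3 stays where compound 2 stands. Compound 3 is expected to give about 100000 nM, with a range from 50000 nM to 300000 nM. The step of a number no higher from compound 2 to compound 3 (the limit leaves the size open) is estimated to be none beyond the scatter, and most likely the assay will again report a limit rather than a number.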

Compound 3, half-maximal inhibitory concentration: 12000 nM
Compound 3: middle estimate off by 8.3-fold (0.92 log units), on the high side, and the stated range ends above it.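

Placing (3-(dimethylamino)propoxy)methyl on this aromatic carbon, in place of dimethylamino, gives an at least 8.3-fold lower number from compound 2 to compound 3 (0.92 log units; beyond the scatter) in this assay, so a change at this position can move the read-out, which the earlier pair could not show. Set against hydrogen on the same carbon, the same chain gives an at least 8.3-fold lower number from compound 1 to compound 3 (0.92 log units; beyond the scatter), so the lower number appears against both smaller groups. Neither step has a known full size, and the step from hydrogen to dimethylamino cannot be read, as both of those compounds rest at a limit of the assay rather than at a number: the limit of > 100000 nM in this assay, at which 2 of the 3 values shown sit.

The compounds shown leave open which part of the new chain goes with the lower number: the ether oxygen, the length of the chain or the dimethylamino group at its end. A plain propoxymethyl group with no amine, a shorter ethoxymethyl chain ending in the same dimethylamino group, or a chain ending in a morpholine ring would begin to separate these parts, and a longer chain would show whether the number keeps falling.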